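The source may hold more compounds than are shown below. What is called first, only, known or untested is meant among the compounds shown, and "the series" means these compounds.

Of the compounds shown here, three sharing one core have been measured in a functional assay on PC-3 cells (Homo sapiens) for antiproliferative activity, read by MTT assay, with a stated time of 72 h; a higher number here means a weaker inhibitor, a lower number a stronger inhibitor. Compound 1 `O=C(COc1ccc(C(=O)/C=C/c2cccc(Cl)c2)cc1)N[C@H]1CCOC1=O` gives 4990 nM, compound 2 `O=C(COc1ccc(C(=O)/C=C/c2ccccc2Cl)cc1)N[C@H]1CCOC1=O` gives 4610 nM, and compound 3 `O=C(COc1ccc(C(=O)/C=C/c2ccc(F)c(F)c2)cc1)N[C@H]1CCOC1=O` gives 21900 nM. Among these three numbers compound 3 stands highest: the step of a 4.4-fold higher number from compound 1 to compound 3 (0.64 log units; beyond the scatter) and the step of a 4.8-fold higher number from compound 2 to compound 3 (0.68 log units; beyond the scatter) are both beyond the scatter, while the step of a 1.1-fold lower number from compound 1 to compound 2 (0.03 log units; within the scatter) lies within it, so compounds 1 and 2 cannot be told apart.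

Compound 4 `COc1ccccc1/C=C/C(=O)c1ccc(OCC(=O)N[C@H]2CCOC2=O)cc1` is the next member. Its difference from compound 3 is 2-methoxyphenyl in place of 3,4-difluorophenyl on a double-bonded chain carbon bound to a double-bonded chain carbon. Within the data shown here, the steps that bear on this change are those that put the 3,4-difluorophenyl group in place of a chlorophenyl group, a 4.4-fold higher number from compound 1 to compound 3 (0.64 log units; beyond the scatter) and a 4.8-fold higher number from compound 2 to compound 3 (0.68 log units; beyond the scatter), each a modest rise in the number. Among the measured compounds shown here, compound 4 removes that 3,4-difluorophenyl group again, and no measured compound carries a 2-methoxyphenyl group, so the nearest guide is a return toward the level of compounds 1 and 2. A modest step downward in this assay is therefore expected, amounting to a 3.7-fold lower number from compound 3 to compound 4 (0.56 log units; beyond the scatter). Compound 4 is estimated to give 6000 nM, with a range from 2500 nM to 15000 nM.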

Compound 4, half-maximal inhibitory concentration: 7240 nM
Compound 4: the middle estimate sits 1.2-fold (0.08 log units) below what was measured, and the stated range covers the measured number.
By their numbers in this assay, from the lowest: compounds 2, 1 and 4 (each within the scatter of the next); then compound 3.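

In this assay, among these compounds, the step of a 3.0-fold lower number from compound 3 to compound 4 (0.48 log units; beyond the scatter) shows that the number falls beyond the scatter when 2-methoxyphenyl replaces 3,4-difluorophenyl on a double-bonded chain carbon bound to a double-bonded chain carbon, and compound 4 is the first compound here whose entering group holds oxygen instead of halogen. The steps of a 1.6-fold higher number from compound 2 to compound 4 (0.20 log units; within the scatter) and a 1.5-fold higher number from compound 1 to compound 4 (0.16 log units; within the scatter) both lie within the scatter, so compound 4 cannot be told apart from compounds 1 and 2, and among these four compounds only compound 3 stands apart, with methoxy and chloro giving indistinguishable numbers in the one direct exchange. No measured information at hand accounts for the separate standing of the 3,4-difluorophenyl group.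

From the compounds shown here alone, whether an amine or a carboxylic acid on this aromatic ring would leave the number at the level of compounds 1, 2 and 4, or move it clearly away in either direction, remains open. Among the compounds shown here, the four compounds also vary only this one group, so the effect of a longer chain in the link to the amide of the shared core is likewise unknown.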